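Chloropyrimidine diamines: methyl removal on the aniline ring

A few compounds are considered here, and "the series" means these few. Any claim that something is new, unique, unknown or untested is made for them only; others in the source may bear on it.

Three measured compounds share a chloropyrimidine diamine core. Compound 1 `Cc1ccccc1Nc1nc(Nc2ccccc2)ncc1Cl` carries an unsubstituted anilino group at one end. In a functional assay on Jurkat cells (Homo sapiens) for inhibition, read by CCK-8 assay, with a stated time of 48 h (on this read-out higher numbers stand for weaker inhibition of growth and lower numbers for stronger inhibition of growth), compound 1 gives only a limit of the assay, > 100000 nM. Compound 2 `Cc1ccc(Nc2ncc(Cl)c(Nc3ccccc3C)n2)cc1` carries a 4-methylphenyl group in its place. In this assay compound 2 likewise gives only a limit, > 100000 nM. The step from compound 2 to compound 1 is hydrogen in place of methyl on an aromatic carbon, and its size is a step that the two limits leave unreadable from compound 2 to compound 1, both ends sitting at the limit of > 100000 nM in this assay, at which 2 of the 3 values shown sit. Compound 3 `Cc1ccccc1Nc1nc(Nc2ccc(N3CCN(C)CC3)cn2)ncc1Cl` differs from compound 2 in more than one place, so the difference between the two cores is not broken down here. In this assay, within the data shown here, compound 3 gives 8080 nM, the only measured number among the three.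

Compound 4 `CN1CCN(c2ccc(Nc3ncc(Cl)c(Nc4ccccc4)n3)nc2)CC1` is not yet measured. It arises from compound 3 by hydrogen in place of methyl on an aromatic carbon. This is the same kind of change as the step from compound 2 to compound 1, but not the same: there the methyl sat para to a large group, here it sits ortho to a large group. The measured pair gives no readable size for the step, so the expectation for compound 4 rests on compound 3 alone, at 8080 nM, and on the small size of the change. The step from compound 3 to compound 4 is expected to be a 1.5-fold higher number from compound 3 to compound 4 (0.17 log units; within the scatter). Compound 4 is therefore expected at about 12000 nM, most likely between 4000 nM and 40000 nM.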

Compound 4, concentration for 50% growth inhibition: > 100000 nM
Compound 4 gave a limit, no number; the forecaster's own chance of this, stated with the estimate: 10%; middle value at least 8.3-fold (0.92 log units) away from the limit.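

Going from (2-methylphenyl)amino to anilino gives, in this assay, an at least 12-fold higher number from compound 3 to compound 4 (1.09 log units; beyond the scatter), so on this core the methyl cannot be lost without a clear drop in growth inhibition. Compound 4 gives only a limit of the assay, > 100000 nM, so this step has a lower bound but no full size. The step from compound 2 to compound 1 cannot be read and concerns a different methyl, so these compounds do not show whether the change carries from one core to another, and most of the set offers no number to compare: the limit of > 100000 nM in this assay, at which 3 of the 4 values shown sit.

Open, from the compounds shown here alone, is whether an ethyl, a methoxy or a chlorine in place of the methyl in the 2-methylphenyl group would hold the value of compound 3 at 8080 nM, or whether only methyl does so. Also open, going by these compounds, is how large the same step would be on a core carrying a morpholine or a longer amine chain, if both ends of the step gave measured numbers rather than limits.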